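Cyano-Fluorophenyl Replacement on a Fused Dihydropyrrolopyrimidine Series

The compounds below may be only part of what the source reports. "The series", "measured", "known", "first", "only" and "open" are said of these compounds alone.

Measured so far in a functional assay on CHO-K1 cells for agonist activity at Glucose-dependent insulinotropic receptor (Homo sapiens), read by a luciferase reporter, with a stated time of 5 h; a higher number here means that more compound is needed for the effect, a lower number that less compound is needed:
compound 1 `CC(C)OC(=O)N1CCC(Oc2ncnc3c2CCN3c2ccc(S(C)(=O)=O)cc2F)CC1` gives 50.1 nM
compound 2 `CC(C)(C)OC(=O)N1CCC(Oc2cccc3c2ccn3-c2ccc(S(C)(=O)=O)cc2)CC1` gives 631 nM
compound 3 `CC(C)OC(=O)N1CCC(Oc2ncnc3c2CCN3c2ccc(S(C)(=O)=O)cc2)CC1` gives 126 nM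

Compound 3 stands second highest of the three numbers in this assay. Its nearest neighbour is compound 1, which differs only in carrying a fluoro on the aromatic ring, and the step is a 2.5-fold higher number from compound 1 to compound 3 (0.40 log units; beyond the scatter). Compound 2, with 631 nM, lies furthest from compound 3.

Compound 4 `CC(C)OC(=O)N1CCC(Oc2ncnc3c2CCN3c2ccc(C#N)cc2F)CC1` differs from compound 3 by 4-cyano-2-fluorophenyl in place of 4-(methylsulfonyl)phenyl on a nitrogen on an aromatic ring in a ring. For the measured compounds named here, the fluoro portion of this change reverses the one measured step, a 2.5-fold higher number from compound 1 to compound 3 (0.40 log units; beyond the scatter), so that portion points toward a lower number. The exchange of methylsulfonyl for cyano has no measured counterpart among these compounds. The expected step is therefore a modest one downward, a 1.6-fold lower number from compound 3 to compound 4 (0.20 log units; within the scatter). For compound 4 the estimate in this assay is 80 nM, expected to fall between 25 nM and 320 nM.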

Compound 4, half-maximal effective concentration: 63.1 nM
Estimate against measurement, compound 4: 1.3-fold (0.10 log units) above; measured number inside the range.
By their numbers in this assay, from the lowest: compounds 1, 4 and 3 (each within the scatter of the next, the first and the last beyond it); then compound 2.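

For the compounds shown here, with the fluoro kept, cyano in place of methylsulfonyl on an aromatic carbon gives a 1.3-fold higher number from compound 1 to compound 4 (0.10 log units; within the scatter) in this assay, so this exchange, which had no measured counterpart earlier, shows no step beyond the scatter. The full exchange of 4-(methylsulfonyl)phenyl for 4-cyano-2-fluorophenyl gives a 2.0-fold lower number from compound 3 to compound 4 (0.30 log units; within the scatter), which also stays within the scatter. Nothing available gives a reason for either result.

The compounds shown leave open how a carboxamide or a methoxy group would compare with the cyano on that aromatic carbon. They also leave open whether a chloro could take the place of the fluoro.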